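From 4-Methoxyphenyl to 3,4-Difluorophenyl on the Carbonyl Carbon

A few compounds are considered here, and "the series" means these few. Any claim that something is new, unique, unknown or untested is made for them only; others in the source may bear on it.

Measured so far:
- compound 1 `COc1ccc(C(=O)/C=C/c2cc(-c3cc(OC)c(OC)c(OC)c3)n[nH]2)cc1OC` gives 92% in a functional assay on KM12 cells (Homo sapiens) for cytotoxicity, read by sulforhodamine B assay, with a stated time of 48 h, tested at 0.1 uM; a lower number here means a stronger effect, a higher number a weaker effect of the compound at the concentration tested
- compound 2 `COc1ccc(C(=O)/C=C/c2cc(-c3cc(OC)c(OC)c(OC)c3)n[nH]2)cc1` gives 94% in this assay

Both measured compounds share a core and differ only in one aromatic ring attached to the carbonyl carbon. The step of a number 2 percentage points higher from compound 1 to compound 2 (within the scatter) is small, so the two values cannot be told apart, and compound 2 stands at the top of these two numbers only by a margin inside the scatter. Both compounds leave most of the cells unaffected at this concentration.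

Compound 3 `COc1cc(-c2cc(/C=C/C(=O)c3ccc(F)c(F)c3)[nH]n2)cc(OC)c1OC` is not yet measured. It differs from compound 2 as follows: 3,4-difluorophenyl in place of 4-methoxyphenyl on a carbonyl carbon. For the measured compounds named here, the only measured step, from compound 1 to compound 2, also changed the same aromatic ring, but only by removing one methoxy group, and it produced no step beyond the scatter. Going by the values given here, no measured step shows what two fluorine atoms in place of the methoxy group do. Given the flatness seen so far, compound 3 is expected to give about 92% in this assay, within 75% to 104%, which means an expected step of a number 2 percentage points lower from compound 2 to compound 3 (within the scatter), nothing beyond the scatter.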

Compound 3, a percentage reported as activity, at one concentration (the size of the read-out at that concentration, not a potency): 92%
For compound 3 middle estimate and measured number coincide at the digits printed; measured number inside the range.
By their numbers in this assay, from the lowest: compounds 1, 3 and 2 (each within the scatter of the next).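

In this assay, 3,4-difluorophenyl on the carbonyl carbon gives a number 2 percentage points lower from compound 2 to compound 3 (within the scatter), and the same group gives no change at the digits printed from compound 1 to compound 3 (within the scatter) when it replaces 3,4-dimethoxyphenyl. For the compounds shown here, the earlier pair showed only that one methoxy group can be removed from this ring without a step beyond the scatter; these steps extend that to a ring with no methoxy group at all, which carries two fluorine atoms instead. At this position and at this single test concentration, the three aromatic groups cannot be told apart, and nothing at hand explains why the read-out stays flat.

As far as these compounds go, it remains open whether a quite different group on this ring, such as an amine or a carboxylic acid, or a longer chain in place of the ring, would produce a step beyond the scatter in this assay. A single concentration also gives no potency, so these three compounds could still differ at higher concentrations, where a change at this position might become visible.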